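Imidazolylalkoxy aryl series: chain homologation from compound 2

A few compounds are considered here, and "the series" means these few. Any claim that something is new, unique, unknown or untested is made for them only; others in the source may bear on it.

In an assay on microsomes from brain (strain Sprague-Dawley) for inhibition of heme oxygenase 2 (Rattus norvegicus), read by spectrophotometry, with a stated time of 60 min (on this read-out higher numbers stand for weaker inhibition and lower numbers for stronger inhibition), compound 1 `Brc1cccc(OCCCCCCn2ccnc2)c1` gives 41000 nM, and compound 2 `Ic1ccc(OCCCCCn2ccnc2)cc1` gives 900 nM; compound 2 holds the lower of the two numbers, but the two compounds differ in more than one place, so their gap is read only as what the two values show. Compound 3 `Ic1ccc(OCCCCCCn2ccnc2)cc1` carries (1H-imidazol-1-yl)methyl in place of 1H-imidazol-1-yl on a saturated chain carbon, five bonds along the chain from an oxygen on an aromatic ring. Among the measured compounds shown here, no single-change step is available among the measured pair, so the expectation for compound 3 rests on compound 2 alone: a modest step in either direction, or none beyond the scatter. Compound 3 is expected at 1500 nM, within 400 nM to 6000 nM, an estimated step of a 1.7-fold higher number from compound 2 to compound 3 (0.22 log units; within the scatter).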

Compound 3, half-maximal inhibitory concentration: > 100000 nM
Compound 3 gave a limit, no number (the forecaster's own chance of this, stated with the estimate: 5%); at least 66-fold (1.82 log units) between middle value and limit.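

(1H-imidazol-1-yl)methyl in place of 1H-imidazol-1-yl on a saturated chain carbon, five bonds along the chain from an oxygen on an aromatic ring, gives an at least 110-fold higher number from compound 2 to compound 3 (2.04 log units; beyond the scatter), so at this position a change of a single chain unit is enough to move the read-out far beyond the scatter. The value of compound 3 is a limit of the assay, not a number, and the true size of the step stays open: the limit of > 100000 nM in this assay, at which 1 of the 3 values shown sits.

Open, from the compounds shown here alone, is whether a shorter chain would match or improve on compound 2 at 900 nM. Also open, going by these compounds, is whether a chloro group in place of the iodo group would keep that value.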